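Trimethoxyphenyl to dimethoxyphenyl: one methoxy removed

The source may hold more compounds than are shown below. What is called first, only, known or untested is meant among the compounds shown, and "the series" means these compounds.

Measured so far in a functional assay on HOP-62 cells (Homo sapiens) for cytotoxicity, read by sulforhodamine B assay, with a stated time of 48 h, tested at 1 uM; on this read-out higher numbers stand for a weaker effect at the one concentration tested and lower numbers for a stronger effect:
compound 1 `COc1ccc(-c2cc(/C=C/C(=O)c3ccc(N)cc3)[nH]n2)cc1` gives 102%
compound 2 `COc1cc(-c2cc(/C=C/C(=O)c3ccc(N)cc3)[nH]n2)cc(OC)c1OC` gives 86%
compound 3 `COc1cc(-c2cc(/C=C/C(=O)c3ccc(F)c(F)c3)[nH]n2)cc(OC)c1OC` gives 94%

Compound 2 gives the lowest of the three numbers in this assay. Its nearest neighbour is compound 3, and a number 8 percentage points higher from compound 2 to compound 3 (within the scatter) lies within the scatter, so the two cannot be ordered. Within the data shown here, compound 1 gives 102%, while compound 2 gives 86%, so compound 1 stands apart by a gap beyond the scatter; compound 1 and compound 2 differ in two places, so no single step connects them.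

Compound 4 `COc1ccc(-c2cc(/C=C/C(=O)c3ccc(N)cc3)[nH]n2)cc1OC` is not yet measured. The change from compound 2 to compound 4 is hydrogen in place of methoxy on an aromatic carbon. Among the measured compounds shown here, no measured step matches this change: the only step available, a number 8 percentage points higher from compound 2 to compound 3 (within the scatter), alters the group on the carbonyl carbon and leaves the methoxy pattern untouched, so it says little here. For the measured compounds named here, the pair compound 1 and compound 2 shows only that removing two methoxy groups goes with a higher number.

Compound 4 is therefore expected to fall between compound 2 and compound 1, with a number 7 percentage points higher from compound 2 to compound 4 (within the scatter) expected to be small. The estimate for compound 4 in this assay is 93%, within 80% to 106%.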

Compound 4, a percentage reported as activity, at one concentration (the size of the read-out at that concentration, not a potency): 92%
For compound 4 the middle estimate is 1 percentage points above the measured one; measured number inside the range.
By their numbers in this assay, from the lowest: compounds 2, 4, 3 and 1 (each within the scatter of the next, the first and the last beyond it).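

In this assay the methoxy pattern can now be read through single-place changes: hydrogen in place of methoxy on an aromatic carbon, ortho to a methoxy group and meta to a large group, gives a number 6 percentage points higher from compound 2 to compound 4 (within the scatter), and methoxy in place of hydrogen on an aromatic carbon gives a number 10 percentage points lower from compound 1 to compound 4 (within the scatter). Among these compounds, each single methoxy step therefore stays inside the scatter, which the earlier compounds could not show because they offered no single step on this group. No measurement shown here accounts for the size of either step.

Still open, going by these compounds, is whether a different group on this aromatic carbon, such as a hydroxy group, a fluorine atom or an ethoxy chain, would give a step beyond the scatter. Also open is whether the 3,4-difluorophenyl group on the carbonyl carbon would give a step of similar size on the core of compound 4, and the single tested concentration gives no measure of potency for any of these compounds.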